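Methoxy added to the methoxyphenyl of compound 1

The source may report more compounds than this note shows. Statements on the series, on what has been measured and on what is new or still open speak of the compounds shown alone.

Three members of the series have numbers in a functional assay on the whole organism (strain albino) for inhibition, with Rattus norvegicus as the target, read by paw edema, with a stated time of 2 h, at a dose of 0.28 mmol/kg by the oral route; on this read-out higher numbers stand for more inhibition at the one dose given (going by the name of the read-out) and lower numbers for less inhibition. Compound 1 `COc1ccc(-c2nnc(SC/C(=N/O)c3ccccc3)n2-c2ccccc2)cc1` gives 63% in this assay. Compound 2 `CCn1c(SCC(=O)c2ccccc2)nnc1-c1ccc(OC)cc1` gives 60% in this assay, and compound 3 `C=CCn1c(SC/C(=N/O)c2ccccc2)nnc1-c1ccc(OC)cc1` gives 66% in this assay. Compound 1 sits in the middle of these three numbers, but both neighbours lie within the usual scatter of it, so the three are not told apart by this read-out. Within the data shown here, the one step that can be followed, a number 3 percentage points higher from compound 1 to compound 3 (within the scatter), changes the group on the aromatic nitrogen and leaves the rest untouched; it does not move the number beyond the scatter.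

Compound 4 `COc1ccc(-c2nnc(SC/C(=N/O)c3ccccc3)n2-c2ccccc2)cc1OC` is the next member. It differs from compound 1 in one place: methoxy in place of hydrogen on an aromatic carbon. Among the measured compounds shown here, no measured pair varies this part of the molecule, so there is no step that bears directly on the change; the only step in hand is small, and the shared core with the oxime-bearing thioether is kept. The expectation is therefore no step beyond the scatter. Compound 4 is expected to give about 63% in this assay, between 50% and 75%. The expected step is no change at the digits printed from compound 1 to compound 4 (within the scatter), within the scatter.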

Compound 4, a percentage reported as inhibition, in the whole organism at one dose (the size of the read-out at that dose, not a potency): 61%
Compound 4: the middle estimate sits 2 percentage points above what was measured; measured number inside the range.
By their numbers in this assay, from the lowest: compounds 2, 4, 1 and 3 (each within the scatter of the next).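

In this assay, the change from 4-methoxyphenyl to 3,4-dimethoxyphenyl gives a number 2 percentage points lower from compound 1 to compound 4 (within the scatter), so a methoxy on this aromatic carbon, ortho to a methoxy group and meta to a large group, leaves the read-out within the scatter at this one dose and time. This is the first reading on the aryl part of the series, as the earlier step varied only the group on the aromatic nitrogen; among the compounds shown, neither place has yet given a step beyond the scatter. No measurement in hand offers an explanation for this result.

As far as these compounds go, whether an amine, a carboxylic acid or a longer chain such as butoxy on this same carbon would move the number beyond the scatter remains open. Also open, from the compounds shown here alone, is whether the added methoxy would read the same with allyl on the aromatic nitrogen, as in compound 3, or with the ketone and ethyl of compound 2.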